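This account rests on a few compounds, and the source may have more. Where it says the series, first, only, none or still open, it means among the compounds named here.

Series notes. Compound 1 `N#Cc1c(-c2ccccc2)cn(-c2ccc(S(=O)(=O)Nc3nccs3)cc2)c1N` carries a free amino group on the shared core; in a functional assay on HepG2 cells (Homo sapiens) for inhibition, read by sulforhodamine B assay, with a stated time of 24 h (a higher number here means a weaker inhibitor, a lower number a stronger inhibitor), compound 1 gives 5360 nM. Compound 2 `N#Cc1c(-c2ccccc2)cn(-c2ccc(S(=O)(=O)Nc3nccs3)cc2)c1NC(N)=O` carries carbamoyl in place of hydrogen on that nitrogen; in this assay compound 2 gives 4020 nM. Compound 2 has a single measured neighbour, compound 1, and the step of a 1.3-fold lower number from compound 1 to compound 2 (0.12 log units; within the scatter) is within the scatter, so the two cannot be told apart on these numbers.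

Compound 3 `CC(=O)Nc1c(C#N)c(-c2ccccc2)cn1-c1ccc(S(=O)(=O)Nc2nccs2)cc1` differs from compound 2 by methyl in place of amino on a carbonyl carbon, which reads ureido to acetamido. Among the compounds with values here, only one measured step exists, and it concerns the same nitrogen; it was within the scatter. Within the data shown here, no measured step bears on the group attached to the carbonyl carbon itself. No change beyond the scatter is therefore expected in this assay, and the expected step is a 1.0-fold lower number from compound 2 to compound 3 (0.00 log units; within the scatter). Compound 3 is estimated at 4000 nM, with an expected range from 1500 nM to 11000 nM.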

Compound 3, half-maximal inhibitory concentration: 4020 nM
Beside the measured number, compound 3's estimate is 1.0-fold (0.00 log units) below it, within the range that was stated.
By their numbers in this assay, from the lowest: compounds 2, 3 and 1 (each within the scatter of the next).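

In this assay, within the data shown here, methyl in place of amino on the carbonyl carbon gives no change at the digits printed from compound 2 to compound 3 (within the scatter), the first measured step at the group on the carbonyl carbon itself; ureido and acetamido cannot be told apart on this number. Acetyl in place of hydrogen on the nitrogen gives a 1.3-fold lower number from compound 1 to compound 3 (0.12 log units; within the scatter), so a second group on that nitrogen also stays within the scatter of the free amino group, and across these three compounds neither position of change separates the numbers. No independent data bear on this result.

On these data alone, whether a longer chain or an amine-bearing chain on the carbonyl carbon would give a step beyond the scatter remains open. Also open, as far as these compounds go, is how a plain methyl on the nitrogen, with no carbonyl, would compare with the free amino group.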